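A few compounds are considered here, and "the series" means these few. Any claim that something is new, unique, unknown or untested is made for them only; others in the source may bear on it.

Working notes on the series.

The shared core is that of compound 1 `COc1ccccc1Nc1cc(C)nc(SCc2nc3ccccc3[nH]2)n1`, which in a functional assay on MGC-803 cells (Homo sapiens) for cytotoxicity, read by MTT assay, with a stated time of 72 h (on this read-out higher numbers stand for weaker inhibition and lower numbers for stronger inhibition), gives 56200 nM. Compound 2 `Cc1cc(Nc2cccc(C(F)(F)F)c2)nc(SCc2nc3ccccc3[nH]2)n1` carries a trifluoromethyl-bearing phenyl on the same ring nitrogen; in this assay compound 2 returns only the limit > 100000 nM, not a number. Compound 3 `Cc1cc(NCCO)nc(SCc2nc3ccccc3[nH]2)n1` carries 2-hydroxyethyl in place of 2-methoxyphenyl on a nitrogen on an aromatic ring. In this assay compound 3 likewise returns only the limit > 100000 nM, so compound 3 stands on the limit and not at a measured number. Among the measured compounds shown here, the one measured step, an at least 1.7-fold higher number from compound 1 to compound 3 (0.25 log units; that floor lies within the scatter), is a floor rather than a size, since it rests on (the limit of > 100000 nM in this assay, at which 2 of the 3 values shown sit).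

Compound 4 `Cc1cc(N2CCCCC2)nc(SCc2nc3ccccc3[nH]2)n1` differs from compound 3 in one place: piperidin-1-yl in place of (2-hydroxyethyl)amino on an aromatic carbon. For the measured compounds named here, no measured step covers this change, and the only step available, from compound 1 to compound 3, ends on a limit. Compound 3 sits at the limit > 100000 nM, so the step of an at least 1.1-fold lower number from compound 3 to compound 4 (0.04 log units; that floor lies within the scatter) is expected to be no larger than the scatter and its direction cannot be read from the numbers shown. For compound 4 in this assay the estimate is 90000 nM, with a range from 30000 nM to 250000 nM, and a real chance that only a limit is reported again.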

Compound 4, half-maximal inhibitory concentration: > 100000 nM
Compound 4: a limit, no number; the forecaster's own chance of this, stated with the estimate: 55%; middle value at least 1.1-fold (0.04 log units) away from the limit.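

Compound 4 is a limit and not a number in this assay: > 100000 nM. So piperidin-1-yl, a six-membered non-aromatic ring with 0 hydrogen-bond donors, does not bring a measured value on this aromatic carbon, just as the open-chain (2-hydroxyethyl)amino with 2 hydrogen-bond donors did not; the step between those two compounds cannot be read, since both are limits. The one readable new step, an at least 1.7-fold higher number from compound 1 to compound 4 (0.25 log units; that floor lies within the scatter), is a floor and not a size, and among the four groups shown on this carbon only (2-methoxyphenyl)amino in compound 1 gives a number, so the picture at this position is largely set by the ceiling of the assay: the limit of > 100000 nM in this assay, at which 3 of the 4 values shown sit.

As far as these compounds go, it remains open whether morpholin-4-yl, a piperazine ring or a longer chain ending in a carboxylic acid on this carbon would give a measured number at all. From the compounds shown here alone, it is equally open whether any change to the shared core, such as replacing the methyl group with an ethyl group, would give a lower number than compound 1 at 56200 nM.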